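The source may report more compounds than this note shows. Statements on the series, on what has been measured and on what is new or still open speak of the compounds shown alone.

Compound 1 `Cn1cc(-c2cnc3ccc(NC(=O)C4CC4)nc3c2)cn1` in a functional assay on HeLa cells (Homo sapiens) for antiproliferative activity, read by MTT assay, with a stated time of 48 h (on this read-out lower numbers stand for stronger inhibition and higher numbers for weaker inhibition), gives > 50000 nM, which is a limit of the assay and not a number.
Compound 2 `Cn1cc(-c2cnc3ccc(NC(=O)c4ccc(F)cc4)nc3c2)cn1` in this assay gives > 50000 nM, again only a limit.

Compound 2 thus stands at the limit, in keeping with the limit of > 50000 nM in this assay, at which 2 of the 2 values shown sit. Compound 3 `COc1ccc(C(=O)Nc2ccc3ncc(-c4cnn(C)c4)cc3n2)cc1` differs from compound 2 by methoxy in place of fluoro on an aromatic carbon. Within the data shown here, the only measured step, a step that the two limits leave unreadable from compound 1 to compound 2, bears on it, and its size cannot be read because both ends are limits. Among the measured compounds shown here, no measured step therefore supports an expectation of change beyond the scatter, so compound 3 is expected to sit at the limit as well. The expected step is a step that the limit leaves unreadable from compound 2 to compound 3. For compound 3 the estimate is 60000 nM, ranging from 25000 nM to 200000 nM.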

Compound 3, half-maximal inhibitory concentration: 4900 nM
Beside the measured number, compound 3's estimate is 12-fold (1.09 log units) above it; measured number below the stated range.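

The group on the carbonyl carbon can change this read-out: in this assay, methoxy in place of fluoro on the aromatic carbon gives an at least 10-fold lower number from compound 2 to compound 3 (1.00 log units; beyond the scatter), and 4-methoxyphenyl in place of cyclopropyl gives an at least 10-fold lower number from compound 1 to compound 3 (1.00 log units; beyond the scatter). Among these compounds, the step between compound 1 and compound 2 cannot be read, so compound 3 is the first to show that this position responds at all. The real sizes of both new steps may be larger, since their starting values are limits: the limit of > 50000 nM in this assay, at which 2 of the 3 values shown sit.

Compound 3 alone carries this change. From the compounds shown here alone, what an amine, a hydroxy group or a longer ether such as ethoxy would give at that same place stays open.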